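Swapping a Cyclobutyl for a Chloropyrazolyl on a Macrolide Amide

A few compounds are considered here, and "the series" means these few. Any claim that something is new, unique, unknown or untested is made for them only; others in the source may bear on it.

Of the compounds shown here, three of a shared macrolide core have been measured in a physicochemical assay for lipophilicity, read by HPLC, measured as chromatographic lipophilicity, at pH 7.4; on this read-out higher numbers stand for higher lipophilicity and lower numbers for lower lipophilicity. Compound 1 `CC[C@H]1OC(=O)[C@H](C)[C@@H](O[C@H]2C[C@@](C)(OC)[C@@H](O)[C@H](C)O2)[C@H](C)[C@@H](O[C@@H]2O[C@H](C)C[C@H](N(C)C)[C@H]2O)[C@](C)(O)C[C@@H](C)CN(CCCNC(=O)C2CCC2)[C@H](C)[C@@H](O)[C@]1(C)O` gives 2.31, compound 2 `CC[C@H]1OC(=O)[C@H](C)[C@@H](O[C@H]2C[C@@](C)(OC)[C@@H](O)[C@H](C)O2)[C@H](C)[C@@H](O[C@@H]2O[C@H](C)C[C@H](N(C)C)[C@H]2O)[C@](C)(O)C[C@@H](C)CN(C)[C@H](C)[C@@H](OCCCNC(=O)C2CCC2)[C@]1(C)O` gives 3.5, and compound 3 `CCCCCCCC(=O)NCCCO[C@H]1[C@H](C)O[C@@H](O[C@H]2[C@H](C)[C@@H](O[C@@H]3O[C@H](C)C[C@H](N(C)C)[C@H]3O)[C@](C)(OC)C[C@@H](C)C(=O)[C@H](C)[C@@H](O)[C@](C)(O)[C@@H](CC)OC(=O)[C@@H]2C)C[C@@]1(C)OC` gives 6.02. Compound 2 therefore stands second highest of the three, beyond the scatter from both neighbours: the nearest is compound 1, lower, and the furthest is compound 3, higher.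

Compound 4 `CC[C@H]1OC(=O)[C@H](C)[C@@H](O[C@H]2C[C@@](C)(OC)[C@@H](O)[C@H](C)O2)[C@H](C)[C@@H](O[C@@H]2O[C@H](C)C[C@H](N(C)C)[C@H]2O)[C@](C)(O)C[C@@H](C)CN(C)[C@H](C)[C@@H](OCCCNC(=O)c2c(C)nn(C)c2Cl)[C@]1(C)O` has not yet been measured. Among the compounds with values here, its single difference from compound 2 is 5-chloro-1,3-dimethyl-1H-pyrazol-4-yl in place of cyclobutyl on a carbonyl carbon. Within the data shown here, no measured pair shows this kind of change. A step of roughly no size beyond the scatter is expected, in either direction, so the expected step of a number 0.10 log units lower from compound 2 to compound 4 (within the scatter) is small. For compound 4 the estimate in this assay is 3.4, with a range from 2.8 to 4.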

Compound 4, distribution coefficient: 3.01
Estimate against measurement, compound 4: 0.39 log units above, and the stated range covers the measured number.
By their numbers in this assay, from the lowest: compound 1; then compound 4; then compound 2; then compound 3.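

In this assay, within the data shown here, 5-chloro-1,3-dimethyl-1H-pyrazol-4-yl in place of cyclobutyl on the carbonyl carbon gives a number 0.49 log units lower from compound 2 to compound 4 (beyond the scatter), the first step at this position that comes from a change in one place. The entering group has more heavy atoms than cyclobutyl and carries hydrogen-bond acceptors, yet the number falls. No measurement shown explains this step.

Still open, from the compounds shown here alone, is how much of the step belongs to the chlorine and how much to the ring, which the same pyrazole without chlorine, or a plain phenyl, could separate. Also open, going by these compounds, is whether an amine on this chain would move the number further.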